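A few compounds are considered here, and "the series" means these few. Any claim that something is new, unique, unknown or untested is made for them only; others in the source may bear on it.

Measured compounds and values:
- compound 1 `Cc1cc(Cl)c(S(C)(=O)=O)cc1C(=O)N=C(N)N` gives 25 nM in a functional assay for inhibition of sodium/hydrogen exchanger (Oryctolagus cuniculus); on this read-out lower numbers stand for stronger inhibition and higher numbers for weaker inhibition
- compound 2 `Cc1cc(-c2ccc(Cl)cc2)c(S(C)(=O)=O)cc1C(=O)N=C(N)N` gives 45 nM in this assay

In this assay compound 2 holds the higher of the two numbers, with compound 1 nearest; the step of a 1.8-fold higher number from compound 1 to compound 2 (0.26 log units; within the scatter) lies within the scatter, so the two cannot be ranked against each other.

Compound 3 `Cc1cc(-c2ccc(F)cc2)c(S(C)(=O)=O)cc1C(=O)N=C(N)N` differs from compound 2 by fluoro in place of chloro on an aromatic carbon. For the measured compounds named here, no measured step touches this exchange of halogens. Going by the values given here, the single measured step, a 1.8-fold higher number from compound 1 to compound 2 (0.26 log units; within the scatter), involves a different part of the molecule and stayed within the scatter, so it offers no lead on direction. Nothing in the series points to a shift beyond the scatter in this assay for compound 3.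

For compound 3 the estimate is 45 nM, with a range from 20 nM to 100 nM. The expected step is therefore no change at the digits printed from compound 2 to compound 3 (within the scatter), no more than the usual spread.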

Compound 3, half-maximal inhibitory concentration: 36 nM
Compound 3: middle estimate off by 1.3-fold (0.10 log units), on the high side; the range from low to high includes it.
By their numbers in this assay, from the lowest: compounds 1, 3 and 2 (each within the scatter of the next).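

In this assay, for the compounds shown here, the first change on the added phenyl ring, 4-chlorophenyl to 4-fluorophenyl, gives a step that stays small (a 1.3-fold lower number from compound 2 to compound 3 (0.10 log units; within the scatter)), so the choice between these two halogens, on an aromatic carbon para to a large group, does not separate the compounds. The 4-fluorophenyl group in place of the chloro of compound 1 also leaves the reading unresolved (a 1.4-fold higher number from compound 1 to compound 3 (0.16 log units; within the scatter)), so a second aryl group at this position shows the same outcome as the first. No supporting measurement accompanies these values.

The compounds shown leave open whether any substituent at this place on the phenyl ring can move the number beyond the scatter, since only chloro and fluoro appear there. An amine, a carboxylic acid or a longer alkyl chain at that carbon would test this directly.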